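Furan-3-yl in Place of 2-Chlorophenyl on the Cyclopropane Carbon

The source may report more compounds than this note shows. Statements on the series, on what has been measured and on what is new or still open speak of the compounds shown alone.

Compound 3 `CC[C@H](C)[C@H](N)CN(C(=O)[C@@H]1C[C@H]1c1ccccc1Cl)c1ccc(-c2ccccc2)cc1` gives in a functional assay for agonist activity at G protein-coupled receptor 88 (Homo sapiens), read by HTRF and cAMP accumulation (on this read-out lower numbers stand for an effect already at smaller amounts and higher numbers for an effect only at larger amounts of compound), only a limit of the assay, > 25000 nM, so its standing among the numbers shown is known only as the limit (the limit of > 25000 nM in this assay, at which 1 of the 3 values shown sits). Compound 1 `CC(C)C[C@@H](N)CN(C(=O)[C@@H]1C[C@H]1c1ccccc1)c1ccc(-c2ccccc2)cc1` gives 1.8 nM and compound 2 `N[C@H](CN(C(=O)[C@@H]1C[C@H]1c1ccccc1)c1ccc(-c2ccccc2)cc1)C1CCCCC1` gives 0.66 nM, with a 2.7-fold lower number from compound 1 to compound 2 (0.44 log units; beyond the scatter); both lack the chlorine that compound 3 carries, and neither pair with compound 3 is a single step. Compound 4 `CC[C@H](C)[C@H](N)CN(C(=O)[C@@H]1C[C@H]1c1ccoc1)c1ccc(-c2ccccc2)cc1` differs from compound 3 by furan-3-yl in place of 2-chlorophenyl on a saturated ring carbon. No measured step covers a change at this saturated ring carbon, so the size and direction of the step to compound 4 cannot be read from the data shown, and a limit may again be reported. From the limit of compound 3 and the much smaller values of compound 1 and compound 2, compound 4 is estimated at 5000 nM, within 100 nM to 30000 nM, which is expected to mean an at least 5.0-fold lower number from compound 3 to compound 4 (0.69 log units; beyond the scatter).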

Compound 4, half-maximal effective concentration: 580 nM
Estimate against measurement, compound 4: 8.6-fold (0.94 log units) above; measured number inside the range.
By their numbers in this assay, from the lowest: compound 2; then compound 1; then compound 4. At a limit, above all of these: compound 3.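

In this assay, going by these compounds alone, furan-3-yl in place of 2-chlorophenyl on the saturated ring carbon gives an at least 43-fold lower number from compound 3 to compound 4 (1.63 log units; beyond the scatter), the only measured step at this position. The change takes the series from a limit to a measured number with the rest of the molecule unchanged, showing that the group on this carbon of the three-membered ring can by itself decide whether a number is obtained at all. The reading for compound 3 is a limit and not a number, so the step has a lower bound only: the limit of > 25000 nM in this assay, at which 1 of the 4 values shown sits.

This one pair changes ring size, removes the chlorine and brings in the ring oxygen all at once, and it cannot separate these differences. As far as these compounds go, what phenyl or thiophen-3-yl would give on this carbon, with the rest of compound 4 kept, remains open.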